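The source may report more compounds than this note shows. Statements on the series, on what has been measured and on what is new or still open speak of the compounds shown alone.

Measured so far:
compound 1, `Cc1cc(NCc2ccncc2)n2nc(C)c(-c3ccccc3)c2n1`: 134000 nM
compound 2, `Cc1cc(NCc2ccccn2)n2ncc(-c3ccc(C(F)(F)F)cc3)c2n1`: < 5000 nM
compound 3, `Cc1cc(NCc2ccccn2)n2ncc(-c3ccc(F)cc3F)c2n1`: < 5000 nM

All three were tested in a physicochemical assay for solubility, read by HPLC, using the shake flask method, measured as kinetic solubility, with a stated time of 2 h, at pH 7.4; a higher number here means a more soluble compound, a lower number a less soluble compound. For the measured compounds named here, compound 1 gives the only real number among them. For compound 2 the result is a limit of the assay, not a number. For compound 3 the result is likewise a limit of the assay. Seen together, compound 1 stands apart from the limit of < 5000 nM in this assay, at which 2 of the 3 values shown sit.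

Compound 4, `Cc1cc(NCc2ncnn2C)n2nc(C)c(-c3ccccc3)c2n1`, has not yet been tested. It differs from compound 1 in one place: 1-methyl-1H-1,2,4-triazol-5-yl in place of pyridin-4-yl on a saturated chain carbon bound to a nitrogen on an aromatic ring.

Going by the values given here, no measured pair shows the effect of such a change, so the expectation rests on compound 1 alone. The step from compound 1 to compound 4 is expected to be small, a 1.2-fold higher number from compound 1 to compound 4 (0.08 log units; within the scatter), within or barely beyond the usual scatter. Compound 4 is therefore estimated at 160000 nM, with a plausible range from 55000 nM to 450000 nM.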

Compound 4, solubility: 185000 nM
Compound 4: the middle estimate sits 1.2-fold (0.06 log units) below what was measured; low and high end bracket the measured number.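

Replacing pyridin-4-yl with 1-methyl-1H-1,2,4-triazol-5-yl on a saturated chain carbon bound to a nitrogen on an aromatic ring gives a 1.4-fold higher number from compound 1 to compound 4 (0.14 log units; within the scatter) in this assay and so leaves the two compounds indistinguishable. At this place, a five-membered aromatic ring with 3 hetero atoms therefore reads like a six-membered aromatic ring with 1 hetero atom. Nothing measured here accounts for this match.

Still open, from the compounds shown here alone, is how a simple amine or a carboxylic acid would read at this place. Also open, going by these compounds, is whether the same swap would give a similar step on compound 2.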